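Three Limits in One Assay and a Fourth Compound Pending

This account rests on a few compounds, and the source may have more. Where it says the series, first, only, none or still open, it means among the compounds named here.

Compound 1, `COc1ncnc2c1c(-c1ccoc1)cn2[C@@H]1O[C@H](CO)[C@@H](O)[C@H]1O`, in a functional assay on CEM-DNR-bulk cells (Homo sapiens), read by MTT assay, with a stated time of 72 h; on this read-out higher numbers stand for weaker inhibition and lower numbers for stronger inhibition: > 20000 nM, a limit of the assay.
Compound 2, `CNc1ncnc2c1c(-c1ccoc1)cn2[C@@H]1O[C@H](CO)[C@@H](O)[C@H]1O`, in this assay: > 20000 nM, a limit of the assay.
Compound 3, `CNc1ncnc2c1c(-c1ccco1)cn2[C@@H]1O[C@H](CO)[C@@H](O)[C@H]1O`, in this assay: > 20000 nM, a limit of the assay.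

The change from compound 2 to compound 1 is methoxy in place of methylamino on an aromatic carbon. The step it made, a step that the two limits leave unreadable from compound 2 to compound 1, has no readable size because the limit of > 20000 nM in this assay, at which 3 of the 3 values shown sit, holds both ends of it. The cores of compound 2 and compound 3 differ as follows: furan-2-yl in place of furan-3-yl on an aromatic carbon. The step that the two limits leave unreadable from compound 2 to compound 3 is likewise not readable in this assay.

Compound 4, `COc1ncnc2c1c(-c1ccco1)cn2[C@@H]1O[C@H](CO)[C@@H](O)[C@H]1O`, has not been measured. It differs from compound 3 by methoxy in place of methylamino on an aromatic carbon, which is the same change, at the same place, as that from compound 2 to compound 1. In this assay compound 4 is expected to give 25000 nM. The expected range for compound 4 runs from 15000 nM to 60000 nM. Set beside the earlier step, the expected step is a step that the limit leaves unreadable from compound 3 to compound 4, and this expectation rests only on (the limit of > 20000 nM in this assay, at which 3 of the 3 values shown sit), since the same change gave compound 1 a value at that limit.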

Compound 4, half-maximal inhibitory concentration: 160 nM
For compound 4 the middle estimate is 160-fold (2.19 log units) above the measured one; the whole stated range lies above it.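

In this assay, methoxy in place of methylamino on an aromatic carbon gave an at least 120-fold lower number from compound 3 to compound 4 (2.09 log units; beyond the scatter), and with methoxy kept, furan-2-yl in place of furan-3-yl gave an at least 120-fold lower number from compound 1 to compound 4 (2.09 log units; beyond the scatter). Among the four compounds, a value off the limit appears only where methoxy and furan-2-yl occur together, and compound 1 and compound 3, each carrying just one of the two groups, show that neither group alone was enough here. This does not show that the change carries over from one core to another with the same size, since the step from compound 2 to compound 1 and the other step between limit values cannot be read, because both ends of each sit at the limit: the limit of > 20000 nM in this assay, at which 3 of the 4 values shown sit.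

The compounds shown leave open whether the result depends on methoxy itself or would also appear with ethoxy or dimethylamino in its place. They also leave open whether furan-2-yl is needed, or whether a thiophene or phenyl group on the same core would give a comparable value.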